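A few compounds are considered here, and "the series" means these few. Any claim that something is new, unique, unknown or untested is made for them only; others in the source may bear on it.

Measured in a functional assay on A549 cells (Homo sapiens) for antiproliferative activity, read by MTT assay, with a stated time of 48 h; a lower number here means a stronger inhibitor, a higher number a weaker inhibitor:

- compound 1 `Cc1cccc(-n2nncc2CN2C(=O)C3(C(C#N)=C(N)Oc4c3c3nc5ccccc5nc3c3ccccc43)c3ccccc32)c1`: 39600 nM
- compound 2 `N#CC1=C(N)Oc2c(c3nc4ccccc4nc3c3ccccc23)C12C(=O)N(Cc1cnnn1-c1ccccc1Br)c1ccccc12`: > 50000 nM, a limit of the assay
- compound 3 `N#CC1=C(N)Oc2c(c3nc4ccccc4nc3c3ccccc23)C12C(=O)N(Cc1cnnn1-c1cccc(Br)c1)c1ccccc12`: > 50000 nM, a limit of the assay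

Compound 3 stands only at the limit of > 50000 nM in this assay, at which 2 of the 3 values shown sit, so no number is known for it. The change to compound 4 `N#CC1=C(N)Oc2c(c3nc4ccccc4nc3c3ccccc23)C12C(=O)N(Cc1cnnn1-c1ccc(N)cc1)c1ccccc12` is 4-aminophenyl in place of 3-bromophenyl on an aromatic nitrogen. All three measured steps alter the same aryl group on the triazole nitrogen, and none of them gives a readable effect: an at least 1.2-fold higher number from compound 1 to compound 3 (0.10 log units; that floor lies within the scatter), an at least 1.2-fold higher number from compound 1 to compound 2 (0.10 log units; that floor lies within the scatter), and a step that the two limits leave unreadable from compound 2 to compound 3. Going by the values given here, the only numeric value in this set, that of compound 1, is itself weak, and the two changes away from it both end at the limit. Among the compounds with values here, for the step from a 3-bromophenyl to a 4-aminophenyl there is thus no measured precedent for a shift beyond the scatter in either direction in this assay. Compound 4 is therefore expected to remain at or near the limit, with an estimated step of a number no higher from compound 3 to compound 4 (the limit leaves the size open), giving an estimate of 50000 nM (range 20000 nM to 200000 nM).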

Compound 4, half-maximal inhibitory concentration: > 50000 nM
Compound 4 ended at the assay's limit; the forecaster's own chance of this, stated with the estimate: 65%; the middle value sits exactly at the limit.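

In this assay, going by these compounds alone, compound 4 joins compound 2 and compound 3 at a limit rather than a number: the limit of > 50000 nM in this assay, at which 3 of the 4 values shown sit A 4-aminophenyl on the triazole nitrogen, with hydrogen-bond donor and acceptor counts that 3-bromophenyl lacks, therefore still gives no readable number at this position, and the comparison with the only numeric value shows an at least 1.2-fold higher number from compound 1 to compound 4 (0.10 log units; that floor lies within the scatter). The steps to it from the two bromophenyl compounds cannot be read, as both ends are limits.

The compounds shown do not tell how far any of the three limit compounds lies beyond the limit, so the true size of these changes stays unknown. From the compounds shown here alone, it also remains open whether a 3-aminophenyl, a 4-methylphenyl or an unsubstituted phenyl on this nitrogen would give a measurable number.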